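A few compounds are considered here, and "the series" means these few. Any claim that something is new, unique, unknown or untested is made for them only; others in the source may bear on it.

Of the compounds shown here, three have been measured in a physicochemical assay for acid dissociation. Compound 1 `CCN(C1=NCCN1)c1c(Br)cccc1Br` gives 11.1; compound 2 `CCCCCN(C1=NCCN1)c1c(Br)cccc1Br` gives 11; compound 3 `CC(C)=CCN(C1=NCCN1)c1c(Br)cccc1Br` gives 10.8. Compound 1 stands at the top of the three numbers, but only by a number 0.10 log units lower from compound 1 to compound 2 (within the scatter) and a number 0.30 log units lower from compound 1 to compound 3 (within the scatter), and the remaining pair shows a number 0.20 log units lower from compound 2 to compound 3 (within the scatter). Going by the values given here, nothing among the measured compounds moves the read-out beyond the scatter.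

Compound 4 `Brc1cccc(Br)c1N(CC1CCCC1)C1=NCCN1` is not yet measured. It differs from compound 1 by cyclopentyl in place of methyl on a saturated chain carbon bound to a nitrogen on an aromatic ring. Among the compounds with values here, the closest precedent is the step from compound 1 to compound 3, which exchanges methyl at the same place, on a saturated chain carbon bound to a nitrogen on an aromatic ring, and reads a number 0.30 log units lower from compound 1 to compound 3 (within the scatter); the chain lengthening in a number 0.10 log units lower from compound 1 to compound 2 (within the scatter) points the same way. On this basis no step beyond the scatter is expected for compound 4 in this assay, which would mean an expected a number 0.10 log units lower from compound 1 to compound 4 (within the scatter). Compound 4 is therefore estimated at 11, with a range from 10.6 to 11.4.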

Compound 4, acid dissociation constant: 10.9
For compound 4 the middle estimate is 0.10 log units above the measured one; the range from low to high includes it.
By their numbers in this assay, from the lowest: compounds 3, 4, 2 and 1 (each within the scatter of the next).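

In this assay a five-membered non-aromatic ring of carbon only now stands on the saturated chain carbon bound to a nitrogen on an aromatic ring, and cyclopentyl in place of methyl reads a number 0.20 log units lower from compound 1 to compound 4 (within the scatter), so this place takes a ring without a step beyond the scatter. Set against the open chains, the ring reads a number 0.10 log units lower from compound 2 to compound 4 (within the scatter) and a number 0.10 log units higher from compound 3 to compound 4 (within the scatter), so cyclopentyl, butyl and 2-methylprop-1-en-1-yl cannot be told apart here by this read-out. No supporting data bear on this result.

All groups shown at this place are built of carbon only, so the reading with an amine or a carboxylic acid on this chain carbon remains open. On these data alone, whether any group here gives a step beyond the scatter also remains open.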